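Adding a second chloro to compound 2

The source may hold more compounds than are shown below. What is called first, only, known or untested is meant among the compounds shown, and "the series" means these compounds.

Measured so far in a functional assay on SGC-7901 cells (Homo sapiens) for antiproliferative activity, read by MTT assay, with a stated time of 72 h; a lower number here means a stronger inhibitor, a higher number a weaker inhibitor:
Compound 1 `COc1ccccc1-c1ccc2ncn(-c3cc(OC)c(OC)c(OC)c3)c2c1` gives 5050 nM
Compound 2 `COc1cc(-n2cnc3ccc(-c4ccc(Cl)cc4)cc32)cc(OC)c1OC` gives 1270 nM

Compound 2 holds the lower of the two numbers, which makes it the stronger inhibitor of the pair. Compound 3 `COc1cc(-n2cnc3ccc(-c4ccc(Cl)cc4Cl)cc32)cc(OC)c1OC` differs from it by chloro in place of hydrogen on an aromatic carbon in one place: chloro in place of hydrogen on an aromatic carbon, ortho to a large group and meta to a chloro group. The 4-chlorophenyl thus becomes 2,4-dichlorophenyl. Within the data shown here, only one measured step bears on this, a 4.0-fold lower number from compound 1 to compound 2 (0.60 log units; beyond the scatter) with 4-chlorophenyl in place of 2-methoxyphenyl. Among the measured compounds shown here, that step swapped one whole group for another, and no measured pair tests a second chloro, so it offers a rough guide to size and no direction. The expected step of a 1.1-fold higher number from compound 2 to compound 3 (0.04 log units; within the scatter) is therefore small, with nothing beyond the scatter expected in this assay here. For compound 3 the estimated value is 1400 nM with an expected range from 500 nM to 3800 nM at its two ends.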

Compound 3, half-maximal inhibitory concentration: > 10000 nM
Compound 3: only a limit was reported (the forecaster's own chance of this, stated with the estimate: 3%); middle value at least 7.1-fold (0.85 log units) away from the limit.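

Among these compounds, a single chloro in place of hydrogen, ortho to a large group and meta to a chloro group, turns the 4-chlorophenyl of the best compound so far into 2,4-dichlorophenyl and gives, in this assay, an at least 7.8-fold higher number from compound 2 to compound 3 (0.89 log units; beyond the scatter), so this position is sensitive to even a one-atom addition, which the earlier swap of one whole group for another could not show. Against the 2-methoxyphenyl group, the same 2,4-dichlorophenyl group gives an at least 1.9-fold higher number from compound 1 to compound 3 (0.29 log units; that floor lies within the scatter), and with that floor inside the scatter, no order can be claimed for this pair. The figure for compound 3 is a limit and not a number: the limit of > 10000 nM in this assay, at which 1 of the 3 values shown sits.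

Still open, as far as these compounds go, is whether only chloro is poorly accepted at this place, or whether a fluoro, a methyl or a hydroxyl would fare the same. A limit also leaves unknown how far the true value of compound 3 lies from that of compound 2.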